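This account rests on a few compounds, and the source may have more. Where it says the series, first, only, none or still open, it means among the compounds named here.

Three compounds share one core and differ only in the chain that ends in carboxy: compound 1 `Nc1nc2[nH]c(CCCCCC(=O)O)cc2c(=O)[nH]1`, compound 2 `Nc1nc2[nH]c(CCCCCCC(=O)O)cc2c(=O)[nH]1` and compound 3 `Nc1nc2[nH]c(CCCCCCCC(=O)O)cc2c(=O)[nH]1`. They are compared in a functional assay on D4 cells (Cricetulus griseus) for inhibition, read by CellTiter-Blue, with a stated time of 96 h; a lower number here means a stronger inhibitor, a higher number a weaker inhibitor. Compound 1 gives > 1000 nM, which is a limit of the assay and not a number. Compound 2 gives > 1000 nM, again a limit and not a number. Compound 2 therefore has no exact position, and the whole picture so far is the limit of > 1000 nM in this assay, at which 2 of the 2 values shown sit.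

The move to compound 3 places carboxymethyl in place of carboxy on a saturated chain carbon, six bonds along the chain from an aromatic carbon. For the measured compounds named here, the only measured step of this kind, made five bonds along the chain from an aromatic carbon, is a step that the two limits leave unreadable from compound 1 to compound 2, so it offers no size to carry over. With compound 2 at > 1000 nM, a limit, no clear change in either direction is expected. The expected move is a step that the limit leaves unreadable from compound 2 to compound 3. For compound 3 the estimated value is 2000 nM, with an expected range from 500 nM to 10000 nM.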

Compound 3, half-maximal inhibitory concentration: > 1000 nM
Compound 3 ended at the assay's limit; the forecaster's own chance of this, stated with the estimate: 90%; the middle value does not contradict the limit.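

No step can be read among compound 1, compound 2 and compound 3, because all three stop at the same limit of this assay, and a limit is not a number: the limit of > 1000 nM in this assay, at which 3 of the 3 values shown sit.

The compounds shown leave open how strong each one actually is, and whether the length of the chain ending in carboxy changes inhibition at all.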